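The source may report more compounds than this note shows. Statements on the series, on what has been measured and on what is new or still open speak of the compounds shown alone.

Working notes on the series. Three compounds share the core of compound 1 `O=C1Nc2ccc(Cl)cc2/C1=N/NC(=S)N1CCN(c2ccccc2)CC1` and differ only in the group on one aromatic carbon of that core. In a functional assay on HCT-116 cells (Homo sapiens) for inhibition, read by MTT assay, with a stated time of 72 h (a higher number here means a weaker inhibitor, a lower number a stronger inhibitor), compound 1 gives 3490 nM. Compound 2 `O=C1Nc2ccc(F)cc2/C1=N/NC(=S)N1CCN(c2ccccc2)CC1` gives 12400 nM, and compound 3 `O=C1Nc2ccc([N+](=O)[O-])cc2/C1=N/NC(=S)N1CCN(c2ccccc2)CC1` gives 15100 nM. Compound 1 stands lowest of the three numbers: the step of a 3.6-fold higher number from compound 1 to compound 2 (0.55 log units; beyond the scatter) and the step of a 4.3-fold higher number from compound 1 to compound 3 (0.64 log units; beyond the scatter) both lie beyond the scatter, while the step of a 1.2-fold higher number from compound 2 to compound 3 (0.09 log units; within the scatter) lies within it, so nothing can be said of order between compound 2 and compound 3.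

Compound 4 `O=C1Nc2ccc(Cl)cc2/C1=N/NC(=S)N1CCN(c2ccccc2F)CC1` is not yet measured. Against compound 1 the difference is fluoro in place of hydrogen on an aromatic carbon, entering on an aromatic carbon of the six-membered aromatic ring of carbon only, ortho to a large group; cut one bond further out it reads phenyl to 2-fluorophenyl. Among the measured compounds shown here, none of the three measured steps touches this part of the molecule; they all move the group on the core, so no measured step bears on the change from compound 1 to compound 4. For the measured compounds named here, with a single small entering group and no comparable step to lean on, the expected step is a 1.0-fold higher number from compound 1 to compound 4 (0.00 log units; within the scatter), with no change beyond the scatter in either direction being the most likely outcome. Compound 4 is therefore estimated at 3500 nM, within the range 1400 nM to 9000 nM.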

Compound 4, half-maximal inhibitory concentration: 8290 nM
The estimate for compound 4 lay 2.4-fold (0.37 log units) below the measured number; the range from low to high includes it.
By their numbers in this assay, from the lowest: compound 1; then compounds 4, 2 and 3 (each within the scatter of the next).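

Working from this assay, the phenyl group of compound 1 proves sensitive to substitution: 2-fluorophenyl in place of phenyl gives a 2.4-fold higher number from compound 1 to compound 4 (0.38 log units; beyond the scatter) as a modest step toward a weaker inhibitor. Among the compounds shown here, the earlier steps moved only the group on the core, so this is the first measured sign that the other end of the molecule also affects the number, even with a single fluoro entering on an aromatic carbon, ortho to a large group. Nothing in hand accounts for the size or direction of this step.

Going by these compounds, whether the step belongs to fluoro itself or to its place remains open, as does whether chloro, methoxy or an amine on this phenyl group would give a step of similar size and direction, or fluoro on another carbon of the ring would do the same. Also open is whether 2-fluorophenyl would give the same step with fluoro or nitro on the core in place of chloro, as it is shown here only with chloro on the core.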